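This account rests on a few compounds, and the source may have more. Where it says the series, first, only, none or still open, it means among the compounds named here.

Measured in a functional assay on NP14 cells (Homo sapiens) for cytotoxicity, read by MTT assay, with a stated time of 48 h; on this read-out higher numbers stand for weaker inhibition and lower numbers for stronger inhibition:
- compound 1 `C=C1CC[C@@H]2[C@](C)(CO)[C@H](O)CC[C@@]2(C)[C@@H]1CCc1ccoc1`: 53300 nM
- compound 2 `C=C1CC[C@@H]2[C@](C)(COC(=O)c3ccc([N+](=O)[O-])cc3)[C@H](O)CC[C@@]2(C)[C@@H]1CCc1ccoc1`: 80900 nM

Compound 1 gives the lowest of these two numbers, but compound 2 lies within the scatter of it, so the two cannot be ranked. Compound 3 `C=C1CC[C@@H]2[C@](C)(CO)[C@H](O)CC[C@@]2(C)[C@@H]1CC(O)c1ccoc1` carries one change from compound 1: hydroxy in place of hydrogen on a saturated chain carbon bound to an aromatic carbon and a saturated chain carbon. This puts hydroxy in place of hydrogen on a saturated chain carbon bound to an aromatic carbon and a saturated chain carbon. Among the compounds with values here, the only measured step, a 1.5-fold higher number from compound 1 to compound 2 (0.18 log units; within the scatter), is a different change at a different place, so it is a loose guide. No shift beyond the scatter is therefore expected in this assay, and no direction can be favoured. The estimated step is a 1.1-fold higher number from compound 1 to compound 3 (0.05 log units; within the scatter). For compound 3 the expected value is 60000 nM, with an estimated range of 28000 nM to 130000 nM.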

Compound 3, half-maximal inhibitory concentration: > 100000 nM
Compound 3 ended at the assay's limit; the forecaster's own chance of this, stated with the estimate: 20%; middle value at least 1.6-fold (0.22 log units) from the limit.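

In this assay, hydroxy in place of hydrogen on this saturated chain carbon bound to an aromatic carbon and a saturated chain carbon gives an at least 1.8-fold higher number from compound 1 to compound 3 (0.27 log units; that floor lies within the scatter). This change therefore brings no stronger inhibition, though the true step may be larger than that floor. For compound 3 the reading is a limit and not a number: the limit of > 100000 nM in this assay, at which 1 of the 3 values shown sits.

As far as these compounds go, the true size of the step stays open. So does whether an amine or a methoxy group on this same carbon would give a lower number than hydroxy does.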